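Swapping the Carbamate Side Group, Judged Against Cytotoxicity Limits

This account rests on a few compounds, and the source may have more. Where it says the series, first, only, none or still open, it means among the compounds named here.

Compound 3 `CC(C)C[C@H](NC(=O)OCc1cccc(F)c1)C(=O)N[C@@H](C[C@@H]1CCNC1=O)C(O)S(=O)(=O)O` carries a 3-fluorobenzyl group on an oxygen next to a carbonyl group. In an ADME assay on HEK-293T cells (Homo sapiens) for cytotoxicity, with a stated time of 72 h (a higher number here means that more compound is tolerated, a lower number that less compound is tolerated), compound 3 gives > 100000 nM, which is a limit of the assay and not a number. Compound 1 `CC(C)C[C@H](NC(=O)OC1CCC(C)(C)CC1)C(=O)N[C@@H](C[C@@H]1CCNC1=O)C(O)S(=O)(=O)O` has a 4,4-dimethylcyclohexyl group at the same place. In this assay compound 1 gives > 100000 nM, again a limit rather than a number. For compound 2 `CC(C)C[C@H](NC(=O)OCC1CCC(F)(F)CC1)C(=O)N[C@@H](C[C@@H]1CCNC1=O)C(O)S(=O)(=O)O` the result in this assay is "not determined" (no result reported); "not determined" (no result reported) (2 entries). Among the compounds with values here, the only step between measured compounds, a step that the two limits leave unreadable from compound 1 to compound 3, therefore has no readable size, and compound 3 stands where most of the known values stand, namely at the limit of > 100000 nM in this assay, at which 2 of the 3 values shown sit.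

The next step replaces the group once more: 1-phenylbutyl in place of 3-fluorobenzyl on an oxygen next to a carbonyl group. This gives compound 4 `CCCC(OC(=O)N[C@@H](CC(C)C)C(=O)N[C@@H](C[C@@H]1CCNC1=O)C(O)S(=O)(=O)O)c1ccccc1`. Within the data shown here, no measured step tells how much a change at this place moves the read-out, and the two measured compounds both sit at the limit of > 100000 nM in this assay, at which 2 of the 3 values shown sit. The expectation for compound 4 is accordingly a tolerated concentration again at or beyond the limit, expressed as 100000 nM with a range from 40000 nM to 300000 nM. The step this estimate means, a number no higher from compound 3 to compound 4 (the limit leaves the size open), is expected to be within the scatter and most likely again reported only as a limit.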

Compound 4, half-maximal cytotoxic concentration: > 100000 nM
Compound 4: only a limit was reported; the forecaster's own chance of this, stated with the estimate: 75%; the middle value lies on the limit itself.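

In this assay compound 4 gives > 100000 nM, a limit and not a number. No step from compound 1 or compound 3 to compound 4 can be read, as all three end at the same point: the limit of > 100000 nM in this assay, at which 3 of the 4 values shown sit.

The compounds shown leave open at what concentration any of them harms these cells, and whether changing the carbamate side group shifts that concentration.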